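The source may report more compounds than this note shows. Statements on the series, on what has been measured and on what is new or still open speak of the compounds shown alone.

In a functional assay on A498 cells (Homo sapiens) for antiproliferative activity (on this read-out higher numbers stand for weaker inhibition of growth and lower numbers for stronger inhibition of growth), compound 3 `c1ccc(-c2cc(-c3ccco3)cc(-c3ccccn3)n2)nc1` gives 0.000064 ug/mL. Compound 1 `c1ccc(-c2cc(-c3ccsc3)cc(-c3ccccn3)n2)nc1` gives 0.000097 ug/mL, and with a 1.5-fold lower number from compound 1 to compound 3 (0.18 log units; within the scatter) the two stand level. Compound 2 `c1ccc(-c2cc(-c3ccccn3)nc(-c3ccccn3)c2)cc1` gives 0.0025 ug/mL, well apart from both, as a 26-fold higher number from compound 1 to compound 2 (1.41 log units; beyond the scatter) and a 39-fold lower number from compound 2 to compound 3 (1.59 log units; beyond the scatter) show. Compound 4 `c1ccc(-c2cc(-c3ccoc3)cc(-c3ccccn3)n2)nc1` differs from compound 3 by furan-3-yl in place of furan-2-yl on an aromatic carbon, with furan-3-yl in place of furan-2-yl on an aromatic carbon. For the measured compounds named here, no measured step makes this exact change. The closest guide is the exchange of thiophen-3-yl for furan-2-yl, a 1.5-fold lower number from compound 1 to compound 3 (0.18 log units; within the scatter), whereas the large steps both involve phenyl, which compound 4 lacks. The expected 1.3-fold higher number from compound 3 to compound 4 (0.10 log units; within the scatter) therefore stays within the scatter. Compound 4 is estimated at 0.00008 ug/mL, with an expected range of 0.00003 ug/mL to 0.0003 ug/mL.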

Compound 4, concentration for 50% growth inhibition: 0.000032 ug/mL
Compound 4: middle estimate off by 2.5-fold (0.40 log units), on the high side; the measured number falls inside the stated range.
By their numbers in this assay, from the lowest: compounds 4, 3 and 1 (each within the scatter of the next, the first and the last beyond it); then compound 2.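

In this assay, furan-3-yl and furan-2-yl stand level on this carbon opposite the ring nitrogen (a 2.0-fold lower number from compound 3 to compound 4 (0.30 log units; within the scatter)), so the point of attachment of the furan makes no difference beyond the scatter. Yet furan-3-yl, unlike furan-2-yl, separates modestly from thiophen-3-yl (a 3.0-fold lower number from compound 1 to compound 4 (0.48 log units; beyond the scatter)), and it stands far from phenyl (a 78-fold lower number from compound 2 to compound 4 (1.89 log units; beyond the scatter)). No evidence is available to explain these differences. Still open, from the compounds shown here alone, is how this position would respond to a non-aromatic group such as an amine, a carboxylic acid or a longer chain.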